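Pyridyl amide swap on the quinoline nitrile series

The source may hold more compounds than are shown below. What is called first, only, known or untested is meant among the compounds shown, and "the series" means these compounds.

In an assay on cells with Cystic fibrosis transmembrane conductance regulator variant F508del (Homo sapiens) as the target, read by fluorescence, with stated times of 24 h and 30 min (on this read-out lower numbers stand for an effect already at smaller amounts and higher numbers for an effect only at larger amounts of compound), compound 1 `Cc1cc(C)c2cc(C#N)c(NCCCNC(=O)c3ccncc3)nc2c1` gives 13200 nM. In this assay compound 3 `Cc1cc(C)c2cc(C#N)c(N3CCN(C(=O)c4ccncc4)CC3)nc2c1` gives 100000 nM, and compound 2 `Cc1cc(C)c2cc(C#N)c(N3CCN(C(=O)c4ccccn4)CC3)nc2c1` gives 100000 nM. The difference between the core of compound 1 and the core of compound 3 is not broken down here. Within the pair compound 3 and compound 2, the change pyridin-2-yl in place of pyridin-4-yl on a carbonyl carbon produced no change at the digits printed from compound 3 to compound 2 (within the scatter). Compound 4 `Cc1cc(C)c2cc(C#N)c(NCCCNC(=O)c3ccccn3)nc2c1` carries the same kind of change against compound 1, namely (pyridin-2-yl in place of pyridin-4-yl on a carbonyl carbon); the place differs in that the carbonyl carbon's other neighbour is an amide-type nitrogen rather than an amide-type nitrogen in a ring. Because the measured pair gave no change at the digits printed from compound 3 to compound 2 (within the scatter), the step expected for compound 4 is a 1.0-fold lower number from compound 1 to compound 4 (0.01 log units; within the scatter). The estimate for compound 4 is 13000 nM, expected to fall between 5000 nM and 35000 nM.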

Compound 4, half-maximal effective concentration: 100000 nM
The estimate for compound 4 lay 7.7-fold (0.89 log units) below the measured number, and the stated range ends below it.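

In this assay, pyridin-2-yl in place of pyridin-4-yl on a carbonyl carbon whose other neighbour is an amide-type nitrogen gives a 7.6-fold higher number from compound 1 to compound 4 (0.88 log units; beyond the scatter). The change does not carry over at the same size from one core to the other: the same change on two cores in this assay, no change at the digits printed (within the scatter) from compound 3 to compound 2 and a 7.6-fold higher number (0.88 log units; beyond the scatter) from compound 1 to compound 4, 7.6-fold (0.88 log units) apart, beyond the scatter of two such steps Within these two pairs the step therefore depends on the core, but the pairs do not show which part of the core matters, and two pairs give no general rule for the series.

Still open, from the compounds shown here alone, is whether a phenyl or thienyl amide on the core of compound 1 keeps the number of compound 1. Also open, going by these compounds, is how a longer chain in place of the chain of compound 1 affects the step.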